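The source may hold more compounds than are shown below. What is called first, only, known or untested is meant among the compounds shown, and "the series" means these compounds.

Among the compounds with values here, in a functional assay on brain (Rattus norvegicus, strain Wistar) for inhibition (a lower number here means a stronger inhibitor, a higher number a weaker inhibitor), three compounds that share one core have numbers so far. Compound 1 `CCCc1ccc(-c2c(C)[nH]c(=O)n2C)cc1`, with a propyl group on an aromatic carbon, gives 21500 nM. Compound 2 `Cc1[nH]c(=O)n(C)c1-c1ccc(CC(C)C)cc1`, with isobutyl in that place, gives 7800 nM, and compound 3 `Cc1[nH]c(=O)n(C)c1-c1ccc(C2CCCCC2)cc1`, with cyclohexyl there, gives 10000 nM. Compound 2 thus stands under compound 1 and level with compound 3, as a 1.3-fold higher number from compound 2 to compound 3 (0.11 log units; within the scatter) shows.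

Compound 4 `Cc1[nH]c(=O)n(C2CCCCC2)c1-c1ccc(CC(C)C)cc1` keeps the isobutyl group of compound 2 and changes another place: cyclohexyl in place of methyl on an aromatic nitrogen. Within the data shown here, no measured step touches that nitrogen, so the evidence is indirect. The nearest guides are a 2.2-fold lower number from compound 1 to compound 3 (0.33 log units; beyond the scatter) and a 2.8-fold lower number from compound 1 to compound 2 (0.44 log units; beyond the scatter), both modest and both made on the aromatic carbon instead. The step between compound 2 and compound 3 goes against any simple trend with group size, showing no change beyond the scatter. A modest fall in the number is therefore expected, held with little confidence. In this assay the expected size is a 2.6-fold lower number from compound 2 to compound 4 (0.41 log units; beyond the scatter). For compound 4 the estimated value is 3000 nM, with an expected range from 600 nM to 12000 nM.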

Compound 4, half-maximal inhibitory concentration: 10900 nM
Compound 4: the middle estimate sits 3.6-fold (0.56 log units) below what was measured; low and high end bracket the measured number.
By their numbers in this assay, from the lowest: compounds 2, 3, 4 and 1 (each within the scatter of the next, the first and the last beyond it).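

Compound 1, compound 2 and compound 3 all carry methyl on the aromatic nitrogen, so they said nothing about that place; their steps came only from the group on the aromatic carbon. The new step gives the first reading there: in this assay, cyclohexyl in place of methyl gives a 1.4-fold higher number from compound 2 to compound 4 (0.15 log units; within the scatter), so replacing 1 heavy atom with 6 heavy atoms and a six-membered non-aromatic ring of carbon only leaves the number within the scatter, with isobutyl held constant on the aromatic carbon. Nothing available accounts for this lack of a measurable change, and this single step cannot show how the number responds across other groups at this place.

The compounds shown leave open whether an ethyl group, a phenyl ring or a chain ending in an amine on that aromatic nitrogen would also stay within the scatter of compound 2. They also leave open whether cyclohexyl on the nitrogen would give a similar step alongside the propyl group of compound 1 or the cyclohexyl group of compound 3, rather than the isobutyl group of compound 2.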